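Ring nitrogen substitution carried onto a second core

This account rests on a few compounds, and the source may have more. Where it says the series, first, only, none or still open, it means among the compounds named here.

Compound 1 `O=C1COc2ccc(-c3cccc(NS(=O)(=O)c4ccc(F)cc4)c3)cc2N1` carries a hydrogen on an amide-type nitrogen in a ring. In a functional assay on A549 cells (Homo sapiens) for antiproliferative activity, read by MTT assay, with a stated time of 72 h (on this read-out higher numbers stand for weaker inhibition and lower numbers for stronger inhibition), compound 1 gives 32100 nM. Compound 2 `O=C1COc2ccc(-c3cccc(NS(=O)(=O)c4ccc(F)cc4)c3)cc2N1c1ccc(Cl)cc1` differs from compound 1 by one change, (4-chlorophenyl in place of hydrogen on an amide-type nitrogen in a ring). In this assay compound 2 gives 31600 nM. The measured step is a 1.0-fold lower number from compound 1 to compound 2 (0.01 log units; within the scatter), so the two values are read as equivalent within the scatter, and no order between compound 1 and compound 2 is claimed.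

Compound 3 `O=C1COc2ccc(-c3cnc4ccccc4c3)cc2N1` rests on a different core; how the two cores differ is not broken down here. In this assay compound 3 returns > 40000 nM, which is a limit of the assay and not a number; (the limit of > 40000 nM in this assay, at which 1 of the 3 values shown sits).

Compound 4 `O=C1COc2ccc(-c3cnc4ccccc4c3)cc2N1c1ccc(Cl)cc1` is not yet measured. It differs from compound 3 by 4-chlorophenyl in place of hydrogen on an amide-type nitrogen in a ring, the same change as that between compound 1 and compound 2, at a place described in identical words. The expected step from compound 3 to compound 4 in this assay is a step that the limit leaves unreadable from compound 3 to compound 4, placed beside the earlier one, resting on compound 1 and compound 2 where a 1.0-fold lower number from compound 1 to compound 2 (0.01 log units; within the scatter) stayed within the scatter. Because compound 3 already sits at > 40000 nM, compound 4 is estimated at 45000 nM, with a range from 22000 nM to 100000 nM, and a limit rather than a number is the likelier outcome.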

Compound 4, half-maximal inhibitory concentration: > 40000 nM
Compound 4: no number, only a limit; the forecaster's own chance of this, stated with the estimate: 70%; the middle value is on the limit's open side.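

Compound 3 and compound 4 both sit at a limit of this assay rather than at a number, so no step from one to the other can be read: the limit of > 40000 nM in this assay, at which 2 of the 4 values shown sit.

The compounds shown leave open whether 4-chlorophenyl in place of hydrogen on an amide-type nitrogen in a ring changes the read-out on the core of compound 3, and what values lie behind the two limits.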